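The source may report more compounds than this note shows. Statements on the series, on what has been measured and on what is new or still open speak of the compounds shown alone.

Three compounds have been measured in an ADME assay on microsomes from liver (Homo sapiens) for metabolic stability, read by LC-MS, using NADPH, with stated times of 5 min and 30 min, tested at 1 uM; on this read-out lower numbers stand for slow clearance and higher numbers for fast clearance:

Compound 1 `CC(c1cc2cccnc2cc1F)n1cnc2ncc(-c3cnn(C)c3)nc21` gives 9 uL/min.
Compound 2 `COC(=O)c1ccc(-c2cnc3ncn(C(C)c4cc5cccnc5cc4F)c3n2)cc1F` gives 73 uL/min.
Compound 3 `CNC(=O)c1ccc(-c2cnc3ncn(C(C)c4cc5cccnc5cc4F)c3n2)cc1F` gives 16 uL/min.

Compound 3 stands second highest of these three numbers. One of the other two lies close to it: a 1.8-fold higher number from compound 1 to compound 3 (0.25 log units; within the scatter). The other lies further off: a 4.6-fold lower number from compound 2 to compound 3 (0.66 log units; beyond the scatter).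

Compound 4 `CC(c1cc2cccnc2cc1F)n1cnc2ncc(-c3ccc(C(N)=O)c(F)c3)nc21` is the next step from compound 3. (hydrogen in place of methyl on an amide-type nitrogen). Among the compounds with values here, no measured step removes a methyl from an amide-type nitrogen, so nothing bears on this change directly. Within the data shown here, the one step that touches the same end of the molecule is the exchange of methylamino for methoxy on the carbonyl carbon, a 4.6-fold lower number from compound 2 to compound 3 (0.66 log units; beyond the scatter), which was modest in size. A hydrogen in place of a methyl is a smaller change than that, and the shared core and the 3-fluorophenyl remain in place, so a step within the scatter, or at most a slightly lower number, is expected in this assay: a 1.3-fold lower number from compound 3 to compound 4 (0.12 log units; within the scatter). Compound 4 is estimated at 12 uL/min, with a range from 6 uL/min to 24 uL/min.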

Compound 4, intrinsic clearance in a liver preparation (reported as CLH), per the amount of preparation that the assay uses: 14 uL/min
Beside the measured number, compound 4's estimate is 1.2-fold (0.07 log units) below it; measured number inside the range.
By their numbers in this assay, from the lowest: compounds 1, 4 and 3 (each within the scatter of the next); then compound 2.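

In this assay, removing the methyl from the amide-type nitrogen gives a 1.1-fold lower number from compound 3 to compound 4 (0.06 log units; within the scatter), so this read-out does not separate methylamino from amino at this position. Amino in place of methoxy on the carbonyl carbon gives a 5.2-fold lower number from compound 2 to compound 4 (0.72 log units; beyond the scatter), which shows that a beyond-scatter step away from compound 2 does not depend on the methyl that compound 3 carries. The swap of the whole group gives a 1.6-fold higher number from compound 1 to compound 4 (0.19 log units; within the scatter), so the 4-carbamoyl-3-fluorophenyl group and the 1-methyl-1H-pyrazol-4-yl group also stay within the scatter of each other. Nothing measured here explains the gap between compound 2 and the two amides. On these data alone, a longer chain such as ethyl on the amide nitrogen, or a carboxylic acid in place of the amide, remains open.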